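The source may hold more compounds than are shown below. What is called first, only, known or untested is meant among the compounds shown, and "the series" means these compounds.

Compound 1, `NC(=O)c1ccccc1NC(=O)COc1ccccc1`, was tested in a functional assay on K562 cells (Homo sapiens) for inhibition, read by trypan blue exclusion, with a stated time of 24 h, tested at 10 uM (on this read-out lower numbers stand for less inhibition of growth and higher numbers for more inhibition of growth at the one concentration tested), where compound 1 gives 57.4%. Compound 2, `Cc1ccccc1OCC(=O)Nc1ccccc1C(N)=O`, differs from compound 1 by methyl in place of hydrogen on an aromatic carbon; in this assay compound 2 gives 19.7%, so that the change produced a number 37.7 percentage points lower from compound 1 to compound 2 (beyond the scatter). Compound 3, `NC(=O)c1cc(I)ccc1NC(=O)COc1ccccc1`, differs from compound 1 by iodo in place of hydrogen on an aromatic carbon; in this assay compound 3 gives 73%, the highest of the three numbers, reached through a number 15.6 percentage points higher from compound 1 to compound 3 (beyond the scatter). Compound 4, `Cc1ccc(OCC(=O)Nc2ccc(I)cc2C(N)=O)cc1`, awaits measurement in this assay. It differs from compound 3 by methyl in place of hydrogen on an aromatic carbon. Going by the values given here, this is the same kind of change as the one from compound 1 to compound 2, but not the same: in compound 2 the methyl sits ortho to a large group, in compound 4 para to a large group. The two cores themselves differ in the way already given for compound 3 against compound 1. Because the earlier methyl step gave a number 37.7 percentage points lower from compound 1 to compound 2 (beyond the scatter), compound 4 is expected to fall from compound 3 by roughly a number 25 percentage points lower from compound 3 to compound 4 (beyond the scatter), though the different place of the methyl leaves that uncertain. Compound 4 is therefore estimated at 48%, between 25% and 72%.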

Compound 4, percent growth inhibition at one concentration: 49.8%
Beside the measured number, compound 4's estimate is 1.8 percentage points below it; the range from low to high includes it.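

In this assay the methyl step on the iodo-bearing core gave a number 23.2 percentage points lower from compound 3 to compound 4 (beyond the scatter). The direction of the earlier methyl step therefore carried over to this second core, but its size did not: the same change on two cores in this assay, a number 37.7 percentage points lower (beyond the scatter) from compound 1 to compound 2 and a number 23.2 percentage points lower (beyond the scatter) from compound 3 to compound 4, 14.5 percentage points apart, beyond the scatter of two such steps This shows that, across these two pairs, methyl in place of hydrogen went with a lower number on both cores, but it does not show that the core alone sets the size of the step, since compound 4 has the methyl para to a large group and compound 2 has it at a different place, and no pair shown has the methyl at the same place on both cores.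

The compounds shown leave open whether a chloro or a methoxy group at these places would also go with a lower number. They also leave open how the series would read with a carboxylic acid in place of the primary amide, or with a longer chain joining the two rings.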